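The source may hold more compounds than are shown below. What is called first, only, known or untested is meant among the compounds shown, and "the series" means these compounds.

Going by the values given here, compound 3 `CC(Oc1ccccc1-c1cccnc1)C1=NCCN1` gives 933 nM in an assay on CHO cells for displacement of a labelled ligand from Alpha-2B adrenergic receptor (Homo sapiens) (a lower number here means a stronger inhibitor, a higher number a weaker inhibitor), which places it second highest of the three numbers so far, with compound 1 `CC(Oc1ccccc1-c1ccccc1O)C1=NCCN1` at 1000 nM and compound 2 `CC(Oc1ccccc1-c1ccc(O)cc1)C1=NCCN1` at 813 nM, both within the scatter of it. Compound 4 `Cc1ccc(-c2ccccc2OC(C)C2=NCCN2)cc1` is the next step: 4-methylphenyl in place of pyridin-3-yl on an aromatic carbon. Two measured steps change the same aryl group on that aromatic carbon, and both stayed within the scatter: a 1.1-fold lower number from compound 1 to compound 3 (0.03 log units; within the scatter) and a 1.1-fold higher number from compound 2 to compound 3 (0.06 log units; within the scatter). None of the measured compounds carries a 4-methylphenyl, so no shown step tests that group directly. For compound 4 a step of a 1.0-fold lower number from compound 3 to compound 4 (0.02 log units; within the scatter) is expected, with no movement beyond the scatter. Compound 4 is therefore estimated at 900 nM, in a range from 350 nM to 2500 nM.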

Compound 4, inhibition constant: 398 nM
Compound 4: middle estimate off by 2.3-fold (0.35 log units), on the high side; the measured number falls inside the stated range.
By their numbers in this assay, from the lowest: compound 4; then compounds 2, 3 and 1 (each within the scatter of the next).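

Changing the aryl group on this aromatic carbon can move the number in this assay beyond the scatter: 4-methylphenyl gives a 2.3-fold lower number from compound 3 to compound 4 (0.37 log units; beyond the scatter) and a 2.5-fold lower number from compound 1 to compound 4 (0.40 log units; beyond the scatter), whereas the steps among the earlier aryl groups all stayed within it. The change can be as small as methyl in place of hydroxy, which gives a 2.0-fold lower number from compound 2 to compound 4 (0.31 log units; beyond the scatter). Nothing given here accounts for these steps.

The compounds shown leave open whether a 4-ethylphenyl, 4-chlorophenyl or 4-aminophenyl group would lower the number further. They also leave open whether the same step holds on a different core.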